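A few compounds are considered here, and "the series" means these few. Any claim that something is new, unique, unknown or untested is made for them only; others in the source may bear on it.

Compound 1 `O=C(c1ccccc1F)N1CCN(c2nc(=O)c3cc(C(F)(F)F)cc([N+](=O)[O-])c3s2)CC1` is the starting point. In an ADME assay on Vero cells (Chlorocebus sabaeus) for cytotoxicity, read by MTT assay, with a stated time of 72 h (a lower number here means that less compound is tolerated, a higher number that more compound is tolerated), compound 1 gives > 125000 nM, which is a limit of the assay rather than a number. Compound 2 `O=C(c1ccc(Cl)cc1)N1CCN(c2nc(=O)c3cc(C(F)(F)F)cc([N+](=O)[O-])c3s2)CC1` gives > 125000 nM in this assay, again a limit. Going by the values given here, compound 3 `O=C(C1CCCCC1)N1CCN(c2nc(=O)c3cc(C(F)(F)F)cc([N+](=O)[O-])c3s2)CC1` gives 88700 nM in this assay, the only number among the three. Between these, a step that the two limits leave unreadable from compound 1 to compound 2, while an at least 1.4-fold lower number from compound 1 to compound 3 (0.14 log units; that floor lies within the scatter) and an at least 1.4-fold lower number from compound 2 to compound 3 (0.14 log units; that floor lies within the scatter); the limit of > 125000 nM in this assay, at which 2 of the 3 values shown sit, caps what can be read from the two aromatic amides.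

Compound 4 `CC(C)CC(=O)N1CCN(c2nc(=O)c3cc(C(F)(F)F)cc([N+](=O)[O-])c3s2)CC1` carries the change (isobutyl in place of 2-fluorophenyl on a carbonyl carbon). Among the compounds with values here, the steps that bear on it are the two that replace an aromatic group on the carbonyl carbon with a non-aromatic one, from compound 1 and from compound 2 to compound 3, both only floors, and both small. He therefore expects in this assay an at least 1.2-fold lower number from compound 1 to compound 4 (0.09 log units; that floor lies within the scatter), a step that may stay hidden within the scatter or at the limit. His estimate for compound 4 is 100000 nM, with a range from 50000 nM to 125000 nM.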

Compound 4, half-maximal cytotoxic concentration: > 125000 nM
Compound 4 was reported as a limit; the forecaster's own chance of this, stated with the estimate: 45%; middle value at least 1.2-fold (0.09 log units) from the limit.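

With isobutyl on the carbonyl carbon, the result shows that an open-chain, non-aromatic group can also reach the ceiling of this assay, which until now only the two aromatic amides had reached. In this assay compound 4 gives > 125000 nM, which is a limit of the assay and not a number. The one readable step is an at least 1.4-fold higher number from compound 3 to compound 4 (0.14 log units; that floor lies within the scatter), while the steps linking compound 4 to the two aromatic amides cannot be read, because both ends of each are limits: the limit of > 125000 nM in this assay, at which 3 of the 4 values shown sit.

Going by these compounds, how far the tolerated concentrations of compound 1, compound 2 and compound 4 extend past that limit remains open. So does whether a longer chain, an amine or a carboxylic acid on this carbonyl carbon would give a readable number in this assay.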